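A few compounds are considered here, and "the series" means these few. Any claim that something is new, unique, unknown or untested is made for them only; others in the source may bear on it.

Measured compounds:
compound 1, `COc1cc2c(Oc3ccc(NC(=O)c4nn(-c5ccccc5)c(=O)cc4C)cc3F)ccnc2cc1OCCCN1CCN(C)CC1`, 350 nM
compound 2, `COc1cc2c(Oc3ccc(NC(=O)c4nn(-c5cccc(F)c5)c(=O)cc4C)cc3F)ccnc2cc1OCCCN1CCCC1`, 170 nM

In a functional assay on A549 cells (Homo sapiens) for inhibition, read by MTT assay, with a stated time of 72 h (a lower number here means a stronger inhibitor, a higher number a weaker inhibitor), compound 2 gives 170 nM, the lowest of the two numbers; its nearest neighbour is compound 1, whose value in this assay is higher by a margin beyond the scatter. Among the compounds with values here, no pair of these two compounds differs in one place only, so no single step is available.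

Compound 3, `COc1cc2c(Oc3ccc(NC(=O)c4nn(-c5cccc(F)c5)c(=O)cc4C)cc3F)ccnc2cc1OCCCN1CCN(C)CC1`, has yet to be measured in this assay. It differs from compound 2 by 4-methylpiperazin-1-yl in place of pyrrolidin-1-yl on a saturated chain carbon, three bonds along the chain from an oxygen on an aromatic ring. Compound 1, which also carries 4-methylpiperazin-1-yl on the same chain, sits higher than compound 2, but the two also differ elsewhere, so that gap cannot be read as the effect of this change alone. The step from compound 2 to compound 3 is expected to be small, at most a modest rise, a 1.5-fold higher number from compound 2 to compound 3 (0.17 log units; within the scatter). Compound 3 is therefore estimated at 250 nM, within a range of 120 nM to 550 nM.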

Compound 3, half-maximal inhibitory concentration: 150 nM
Compound 3: middle estimate off by 1.7-fold (0.22 log units), on the high side; low and high end bracket the measured number.
By their numbers in this assay, from the lowest: compounds 3 and 2 (each within the scatter of the next); then compound 1.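

In this assay, 4-methylpiperazin-1-yl in place of pyrrolidin-1-yl on this saturated chain carbon makes no difference beyond the scatter, with a 1.1-fold lower number from compound 2 to compound 3 (0.05 log units; within the scatter). The other single change does lie beyond the scatter: fluoro in place of hydrogen on an aromatic carbon gives a 2.3-fold lower number from compound 1 to compound 3 (0.37 log units; beyond the scatter), so among these three compounds, the step that exceeds the scatter is the fluoro change rather than the amine change. No measurement is available to explain either step.

The compounds shown leave open whether the amine change would remain as small with hydrogen in place of the fluoro, and whether fluoro would give a similar step on another aromatic carbon. They also leave open how a morpholin-4-yl group or a dimethylamino group would compare on the same chain, or how either amine would behave on a shorter or longer chain.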